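Removing the Methoxy from Compound 2: What to Expect

The source may hold more compounds than are shown below. What is called first, only, known or untested is meant among the compounds shown, and "the series" means these compounds.

Compound 1 `COc1ccc2oc(/C=C/c3ccc(OC(F)(F)F)cc3)cc(=O)c2c1` sits at a limit in a functional assay on A549 cells (Homo sapiens) for antiproliferative activity, read by MTT assay, with a stated time of 12 h; a higher number here means a weaker inhibitor, a lower number a stronger inhibitor: compound 1 gives > 40000 nM.
Compound 2 `COc1ccc2c(=O)cc(/C=C/c3ccc(OC(F)(F)F)cc3)oc2c1` also sits at a limit: in this assay compound 2 gives > 40000 nM.
Compound 3 `COc1ccc2c(=O)cc(/C=C/c3ccc(OC(F)(F)F)cc3)oc2c1OC` sits at a limit too: in this assay compound 3 gives > 40000 nM.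

Compound 2 stands only at a limit in this assay, as do the other two, a position summed up by the limit of > 40000 nM in this assay, at which 3 of the 3 values shown sit. The step that the two limits leave unreadable from compound 2 to compound 3 cannot be read in size. Compound 4 `O=c1cc(/C=C/c2ccc(OC(F)(F)F)cc2)oc2ccccc12` differs from compound 2 by hydrogen in place of methoxy on an aromatic carbon. Within the data shown here, no measured step bears on this change in a readable way, so no direction can be drawn from the numbers. Compound 4 is therefore expected to remain near the same limit, with the step of a number no higher from compound 2 to compound 4 (the limit leaves the size open) expected to be within the scatter. The estimate for compound 4 is 40000 nM, ranging from 10000 nM to 100000 nM.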

Compound 4, half-maximal inhibitory concentration: 15600 nM
Estimate against measurement, compound 4: 2.6-fold (0.41 log units) above; measured number inside the range.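

Hydrogen in place of methoxy gives an at least 2.5-fold lower number from compound 2 to compound 4 (0.40 log units; beyond the scatter), and the same change gives an at least 2.5-fold lower number from compound 1 to compound 4 (0.40 log units; beyond the scatter), so a lower number is reached from both of these methoxy compounds. Compound 4 is the only one of the compounds shown to give a readable number in this assay: the limit of > 40000 nM in this assay, at which 3 of the 4 values shown sit. Each step is a minimum, as it starts from a limit, and its full size cannot be read. The compounds shown leave open whether an amine or a hydroxyl group on this aromatic carbon would give a number like that of compound 4. They also leave open whether changes elsewhere on compound 4 would lower its number.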